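Chloro on the Anilino Ring Where Only Limits Are Read

The source may report more compounds than this note shows. Statements on the series, on what has been measured and on what is new or still open speak of the compounds shown alone.

The three measured compounds share one core, and in a functional assay on NCI-H460 cells (Homo sapiens) for cytotoxicity, read by MTT assay (on this read-out lower numbers stand for stronger inhibition and higher numbers for weaker inhibition), compound 1 `COc1cccc(/C=C/C(=O)c2sc(Nc3ccc(Cl)cc3)nc2C)c1` gives only a limit, > 25000 nM. Compound 2 `COc1cccc(/C=C/C(=O)c2sc(Nc3ccccc3)nc2C)c1` likewise gives only a limit in this assay, > 25000 nM. Compound 3 `Cc1nc(Nc2cccc(Cl)c2)sc1C(=O)/C=C/c1ccc(Cl)cc1` also reaches only a limit there, > 25000 nM. The difference between the core of compound 2 and that of compound 3 is not broken down here. From compound 2 to compound 1 the change is chloro in place of hydrogen on an aromatic carbon and the step that the two limits leave unreadable from compound 2 to compound 1, which cannot be read because of the limit of > 25000 nM in this assay, at which 3 of the 3 values shown sit. Compound 4 `Cc1nc(Nc2ccc(Cl)c(Cl)c2)sc1C(=O)/C=C/c1ccc(Cl)cc1` carries the same kind of change, (chloro in place of hydrogen on an aromatic carbon), here ortho to a chloro group as well as para to a large group. In this assay a step that the limit leaves unreadable from compound 3 to compound 4 is expected, resting on compound 1 sitting at the limit of > 25000 nM in this assay, at which 3 of the 3 values shown sit. Compound 4 is therefore estimated at 30000 nM, between 8000 nM and 100000 nM.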

Compound 4, half-maximal inhibitory concentration: > 25000 nM
Compound 4: no number, only a limit; the forecaster's own chance of this, stated with the estimate: 70%; the middle value does not contradict the limit.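

No new step can be read between compound 3 and compound 4 in this assay, because both compounds give only a limit: the limit of > 25000 nM in this assay, at which 4 of the 4 values shown sit.

The compounds shown leave open how large any effect of chloro in place of hydrogen on an aromatic carbon is in this assay.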